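Swapping methoxyphenyl for difluorophenyl in the cytotoxicity series

The source may hold more compounds than are shown below. What is called first, only, known or untested is meant among the compounds shown, and "the series" means these compounds.

Compound 1 `O=C1C(=Cc2ccc(F)cc2)C(=O)N(c2ccc(Cl)cc2)N1c1ccc(Cl)cc1`: 26000 nM
Compound 2 `COc1cc(C=C2C(=O)N(c3ccc(Cl)cc3)N(c3ccc(Cl)cc3)C2=O)ccc1O`: 21800 nM
Compound 3 `COc1ccc(C=C2C(=O)N(c3ccc(Cl)cc3)N(c3ccc(Cl)cc3)C2=O)cc1`: > 128000 nM

In a functional assay on MGC-803 cells (Homo sapiens) for cytotoxicity, read by MTT assay, with a stated time of 72 h (on this read-out lower numbers stand for stronger inhibition and higher numbers for weaker inhibition), compound 1 gives 26000 nM and compound 2 gives 21800 nM. For compound 3 the number is only a limit of this assay, > 128000 nM, so compound 3 stands at the weak end of what is shown (the limit of > 128000 nM in this assay, at which 1 of the 3 values shown sits). Compound 4 `O=C1C(=Cc2ccc(F)cc2F)C(=O)N(c2ccc(Cl)cc2)N1c1ccc(Cl)cc1` differs from compound 3 by 2,4-difluorophenyl in place of 4-methoxyphenyl on a double-bonded chain carbon bound to a double-bonded ring carbon. The measured steps that bear on this are an at least 4.9-fold higher number from compound 1 to compound 3 (0.69 log units; beyond the scatter) and an at least 5.8-fold higher number from compound 2 to compound 3 (0.76 log units; beyond the scatter), both toward a higher number when a methoxy-bearing ring replaces a fluorine-bearing one. Reversing that, the estimate for compound 4 is a lower number, an at least 5.1-fold lower number from compound 3 to compound 4 (0.70 log units; beyond the scatter), close to compound 1. Compound 4 is therefore expected to give about 25000 nM, within 10000 nM to 70000 nM.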

Compound 4, half-maximal inhibitory concentration: 35700 nM
Compound 4: middle estimate off by 1.4-fold (0.15 log units), on the low side; low and high end bracket the measured number.
By their numbers in this assay, from the lowest: compounds 2, 1 and 4 (each within the scatter of the next). At a limit, above all of these: compound 3.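

In this assay, a further fluorine on the ring at this position, a double-bonded chain carbon bound to a double-bonded ring carbon, stays within the scatter (a 1.4-fold higher number from compound 1 to compound 4 (0.14 log units; within the scatter)), and 2,4-difluorophenyl reads level with 4-hydroxy-3-methoxyphenyl (a 1.6-fold higher number from compound 2 to compound 4 (0.21 log units; within the scatter)). Only 4-methoxyphenyl stands apart, with 2,4-difluorophenyl in its place giving a clear shift (an at least 3.5-fold lower number from compound 3 to compound 4 (0.55 log units; beyond the scatter)). Going by these compounds, the value of compound 3 is only a limit of the assay, so the true size of that shift stays unknown. On these data alone, whether an amine or a carboxylic acid on this ring would give a lower number remains open.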